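Benzyl substitution on the aromatic nitrogen of compound 1

A few compounds are considered here, and "the series" means these few. Any claim that something is new, unique, unknown or untested is made for them only; others in the source may bear on it.

In a functional assay on Bel-7402 cells (Homo sapiens) for antiproliferative activity, read by MTT assay, with a stated time of 72 h (on this read-out higher numbers stand for weaker inhibition and lower numbers for stronger inhibition), compound 1 (`C=C1C(=O)O[C@H]2[C@H]1CC/C(COC(=O)Cn1cc(F)c(=O)[nH]c1=O)=C\CC[C@@]1(C)O[C@@H]21`) gives > 20000 nM, which is a limit and not a number. Compound 2 (`C=C1C(=O)O[C@H]2[C@H]1CC/C(COC(=O)CCC(=O)N1CCN(C(=O)Cn3cc(F)c(=O)[nH]c3=O)CC1)=C\CC[C@@]1(C)O[C@@H]21`) gives > 20000 nM, also a limit. Compound 1 thus stands at the limit of > 20000 nM in this assay, at which 2 of the 3 values shown sit. Compound 3 (`C=C1C(=O)O[C@H]2[C@H]1CC/C(COC(=O)CCC(=O)NCCCCCCNC(=O)Cn1cc(F)c(=O)n(Cc3ccccc3)c1=O)=C\CC[C@@]1(C)O[C@@H]21`) alone reads as a number, at 18300 nM.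

Compound 4 (`C=C1C(=O)O[C@H]2[C@H]1CC/C(COC(=O)Cn1cc(F)c(=O)n(Cc3ccc(F)cc3)c1=O)=C\CC[C@@]1(C)O[C@@H]21`) departs from compound 1 by a single change: 4-fluorobenzyl in place of hydrogen on an aromatic nitrogen. 4-Fluorobenzyl takes the place of hydrogen on an aromatic nitrogen. Going by the values given here, no measured pair isolates this change. The nearest guide is compound 3 at 18300 nM, which also carries a benzyl group on that nitrogen, though with a different chain. Only a small move towards stronger inhibition in this assay is therefore expected, perhaps none beyond the scatter, and the reading may remain a limit. The expected step is an at least 1.4-fold lower number from compound 1 to compound 4 (0.15 log units; that floor lies within the scatter). For compound 4 the estimated value is 14000 nM, with an expected range from 5000 nM to 30000 nM.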

Compound 4, half-maximal inhibitory concentration: 2730 nM
Compound 4: the middle estimate sits 5.1-fold (0.71 log units) above what was measured; the whole stated range lies above it.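

In this assay, going by these compounds alone, 4-fluorobenzyl in place of hydrogen on the aromatic nitrogen gives an at least 7.3-fold lower number from compound 1 to compound 4 (0.86 log units; beyond the scatter), the first step that isolates this position. The nitrogen therefore accepts a group of this size, one six-membered aromatic ring two atoms away from it, with the read-out moving from a limit to a number. The true size of the step remains unknown, because compound 1 reads only as a limit: the limit of > 20000 nM in this assay, at which 2 of the 4 values shown sit.

The compounds shown leave open whether the step belongs to the benzyl group itself or to its fluoro group, a question that plain benzyl on the core of compound 1 would settle. Also open, going by these compounds, is how a methyl group, a longer alkyl chain, or a benzyl group carrying an amine or a carboxylic acid would read on this nitrogen.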